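The source may report more compounds than this note shows. Statements on the series, on what has been measured and on what is new or still open speak of the compounds shown alone.

Measured compounds:
- compound 1 `COc1cc(-c2nn(-c3cccc(NC(=O)c4cccc(C(F)(F)F)c4)c3)cc2-c2ccncc2)ccc1Cl` — 10800 nM
- compound 2 `O=C(Nc1cccc(-n2cc(-c3ccncc3)c(-c3ccc(Cl)c(O)c3)n2)c1)Nc1ccc(Cl)c(Cl)c1` — 2890 nM

In a functional assay on NCI-H322M cells (Homo sapiens) for inhibition, read by sulforhodamine B assay, with a stated time of 48 h (a higher number here means a weaker inhibitor of growth, a lower number a stronger inhibitor of growth), compound 1 gives 10800 nM, the higher of the two numbers at hand. Compound 2 gives 2890 nM in this assay, and the gap between the two values lies beyond the usual scatter; the two structures differ in several places, so no single change can be read from them.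

Compound 3 `COc1cc(-c2nn(-c3cccc(NC(=O)Nc4cccc(C(F)(F)F)c4)c3)cc2-c2ccncc2)ccc1Cl` differs from compound 1 in one place only: (3-(trifluoromethyl)phenyl)amino in place of 3-(trifluoromethyl)phenyl on a carbonyl carbon. The change turns the amide into a urea, and compound 2 likewise carries a urea, although its other parts differ too. On that slender basis a modest downward step is expected, from compound 1 to compound 3, of a 2.2-fold lower number from compound 1 to compound 3 (0.33 log units; beyond the scatter) in this assay, possibly no larger than the scatter. Compound 3 is therefore estimated at 5000 nM in this assay, within a range from 1500 nM to 16000 nM.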

Compound 3, concentration for 50% growth inhibition: 1210 nM
Estimate against measurement, compound 3: 4.1-fold (0.62 log units) above; the measured number lies below the stated range.
By their numbers in this assay, from the lowest: compound 3; then compound 2; then compound 1.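

In this assay, among these compounds, (3-(trifluoromethyl)phenyl)amino in place of 3-(trifluoromethyl)phenyl on a carbonyl carbon gives an 8.9-fold lower number from compound 1 to compound 3 (0.95 log units; beyond the scatter), the first step here that can be read at a single place, and it shows that this position responds to the change. The 3-(trifluoromethyl)phenyl ring is present on both sides of the step, so the two compounds are separated only by the added amino nitrogen, which brings one hydrogen-bond donor by the count. No measurement at hand says why the step has this size.

The compounds shown leave open whether the lower number depends on that nitrogen as such, or whether an oxygen in the same place, giving a carbamate, or a methylene link would serve as well. Also open, going by these compounds, is how a methyl group on that nitrogen would change the number.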